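A few compounds are considered here, and "the series" means these few. Any claim that something is new, unique, unknown or untested is made for them only; others in the source may bear on it.

Values in a functional assay on HMEC-1 cells (Homo sapiens) for antiproliferative activity, read by cell counting, with a stated time of 7 days; on this read-out higher numbers stand for weaker inhibition and lower numbers for stronger inhibition:

- Compound 1 `CCOC(=O)CN(Cc1cc(F)cc(F)c1)c1ccc2c(c1)OC(C)(COc1ccc(C#N)cc1)CN2C`: 49000 nM
- Compound 2 `CCOC(=O)CN(Cc1cc(F)cc(F)c1)c1ccc2c(c1)N(C)CC(C)(COc1ccc(C#N)cc1)O2`: > 100000 nM (a limit of the assay, not a number)
- Compound 3 `CCOC(=O)CN(Cc1cccc(F)c1)c1ccc2c(c1)N(C)CC(C)(COc1ccc(C(=N)N)cc1)O2`: 6000 nM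

Compound 3 has the lowest number here, and the gap to compound 1, its nearest neighbour, lies beyond the usual scatter. Compound 4 `CCOC(=O)CN(Cc1cccc(F)c1)c1ccc2c(c1)N(C)CC(C)(COc1ccc(C#N)cc1)O2` is compound 3 with one change on an aromatic carbon, para to a large group: cyano enters in place of a group with no common name (a group of 2 heavy atoms (1 carbon, 1 nitrogen; no ring) in place of a group of 3 heavy atoms (1 carbon, 2 nitrogen; no ring), on an aromatic carbon). For the measured compounds named here, no measured pair shows this change alone. Compound 1 also carries cyano, differs elsewhere too, and gives 49000 nM, a higher number than compound 3. Compound 2, also with cyano, stands at a limit. An upward step beyond the scatter is expected, estimated as a 10-fold higher number from compound 3 to compound 4 (1.00 log units; beyond the scatter) in this assay. The expected value for compound 4 is 60000 nM, with an estimated range from 20000 nM to 150000 nM.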

Compound 4, half-maximal inhibitory concentration: > 100000 nM
Compound 4 gave a limit, no number; the forecaster's own chance of this, stated with the estimate: 35%; at least 1.6-fold (0.22 log units) between middle value and limit.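

In this assay, the group of 3 heavy atoms and cyano can now be compared directly on this aromatic carbon, with no other difference between the compounds, and the swap to cyano gives an at least 16-fold higher number from compound 3 to compound 4 (1.22 log units; beyond the scatter). Compound 4 stands at a limit of the assay, not at a number, and such limits are common in this small set: the limit of > 100000 nM in this assay, at which 2 of the 4 values shown sit. The step for hydrogen in place of fluoro cannot be read, as it joins two limits.

Going by these compounds, what an amine or a carboxylic acid on this aromatic carbon would give stays open. On these data alone, whether the same swap has a similar effect with other groups elsewhere on the shared core also stays open.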